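The source may hold more compounds than are shown below. What is called first, only, known or untested is meant among the compounds shown, and "the series" means these compounds.

Three analogues of the shared core differ only in the group on the hydrazone carbon. Compound 1 `COc1ccc(/C=N/Nc2ncc(Cl)c(Nc3cccc(NC(=O)/C=C/CN(C)C)c3)n2)cc1` gives 4820 nM in an ADME assay on HT-29 cells (Homo sapiens) for inhibition, read by MTT assay, with a stated time of 72 h; a lower number here means a stronger inhibitor, a higher number a weaker inhibitor. Compound 2 `CN(C)C/C=C/C(=O)Nc1cccc(Nc2nc(N/N=C/c3ccncc3)ncc2Cl)c1` gives 25200 nM in this assay, and compound 3 `CN(C)C/C=C/C(=O)Nc1cccc(Nc2nc(N/N=C/c3c[nH]c4ccccc34)ncc2Cl)c1` gives 9680 nM. Compound 3 thus stands second highest of the three numbers, nearest to compound 1 and furthest from compound 2. The measured steps run a 5.2-fold higher number from compound 1 to compound 2 (0.72 log units; beyond the scatter), a 2.0-fold higher number from compound 1 to compound 3 (0.30 log units; within the scatter) and a 2.6-fold lower number from compound 2 to compound 3 (0.42 log units; beyond the scatter). Compound 4 `COc1cccc(/C(C)=N/Nc2ncc(Cl)c(Nc3cccc(NC(=O)/C=C/CN(C)C)c3)n2)c1` is not yet measured; it differs from compound 3 by a group of 11 heavy atoms (9 carbon, 1 nitrogen, 1 oxygen; one six-membered aromatic ring of carbon only) in place of a group of 11 heavy atoms (9 carbon, 2 nitrogen; one five-membered aromatic ring with 1 hetero atom, one six-membered aromatic ring of carbon only), on a nitrogen on an aromatic ring. The step that bears most closely on this change, a 2.0-fold higher number from compound 1 to compound 3 (0.30 log units; within the scatter), stayed within the scatter. For compound 4 the expected step is a 1.8-fold lower number from compound 3 to compound 4 (0.25 log units; within the scatter), a move toward a lower number that need not exceed the scatter. Compound 4 is therefore estimated at 5500 nM, within 1800 nM to 17000 nM.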

Compound 4, half-maximal inhibitory concentration: 3870 nM
For compound 4 the middle estimate is 1.4-fold (0.15 log units) above the measured one, and the stated range covers the measured number.
By their numbers in this assay, from the lowest: compounds 4, 1 and 3 (each within the scatter of the next, the first and the last beyond it); then compound 2.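

At this position, on a nitrogen on an aromatic ring, replacing the 1H-indol-3-yl-bearing group with the group of 11 heavy atoms containing one oxygen gives a 2.5-fold lower number from compound 3 to compound 4 (0.40 log units; beyond the scatter), so a change of this group can exceed the scatter even at equal heavy-atom count. For the compounds shown here, the largest step so far is a 6.5-fold lower number from compound 2 to compound 4 (0.81 log units; beyond the scatter), whereas a 1.2-fold lower number from compound 1 to compound 4 (0.10 log units; within the scatter) leaves the two methoxy-type groups unseparated. No measurement available here explains these steps. As far as these compounds go, whether an amine or a carboxylic acid on the aromatic ring of this group would shift the number in this assay remains open.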